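Carbonyl substituent changes on a shared core

The source may report more compounds than this note shows. Statements on the series, on what has been measured and on what is new or still open speak of the compounds shown alone.

Compound 3 `Cc1ccc(C(=O)Nc2ccc3[nH]cc(C4CCN(C)CC4)c3n2)cc1` gives 12 nM in an assay for binding affinity to 5-hydroxytryptamine receptor 1F (Homo sapiens), read by radioligand binding; a higher number here means a weaker inhibitor, a lower number a stronger inhibitor. It stands at the top of the three numbers only nominally: a 1.2-fold higher number from compound 1 to compound 3 (0.09 log units; within the scatter) and a 1.1-fold higher number from compound 2 to compound 3 (0.04 log units; within the scatter) are both within the scatter, so compound 1 `CN1CCC(c2c[nH]c3ccc(NC(=O)C4CC4)nc23)CC1` with 9.8 nM and compound 2 `CN1CCC(c2c[nH]c3ccc(NC(=O)c4cccc(F)c4)nc23)CC1` with 11 nM cannot be separated from it. Compound 4 `CN1CCC(c2c[nH]c3ccc(NC(=O)Nc4ccc(F)cc4)nc23)CC1` differs from compound 3 at the same place varied among the measured compounds: (4-fluorophenyl)amino in place of 4-methylphenyl on a carbonyl carbon. Among the measured compounds shown here, the steps that bear on this are a 1.1-fold higher number from compound 1 to compound 2 (0.05 log units; within the scatter), a 1.2-fold higher number from compound 1 to compound 3 (0.09 log units; within the scatter) and a 1.1-fold higher number from compound 2 to compound 3 (0.04 log units; within the scatter); all three exchange one carbonyl substituent for another and none leaves the scatter. What none of them covers is an entering group that carries a hydrogen-bond donor, so the measured steps support tolerance of the substituent but not this particular change directly. For this assay no step beyond the scatter is expected, and a 1.2-fold higher number from compound 3 to compound 4 (0.07 log units; within the scatter) is the estimated outcome. Compound 4 is therefore expected to give about 14 nM, with a range of 5 nM to 45 nM to allow for the unmeasured donor.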

Compound 4, inhibition constant: 11 nM
Beside the measured number, compound 4's estimate is 1.3-fold (0.10 log units) above it; the measured number falls inside the stated range.
By their numbers in this assay, from the lowest: compounds 1, 2, 4 and 3 (each within the scatter of the next).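

Placing (4-fluorophenyl)amino on the carbonyl carbon gives this position its first hydrogen-bond donor among the compounds shown, yet this assay shows no step beyond the scatter (a 1.1-fold lower number from compound 3 to compound 4 (0.04 log units; within the scatter); no change at the digits printed from compound 2 to compound 4 (within the scatter); a 1.1-fold higher number from compound 1 to compound 4 (0.05 log units; within the scatter)). The tolerance seen among cyclopropyl, 3-fluorophenyl and 4-methylphenyl therefore extends to a group attached through nitrogen rather than carbon, and none of the four compounds goes against it. No available measurement accounts for this lack of response.

As far as these compounds go, all four substituents are a small carbocycle, an aromatic ring or an aromatic ring on an amino link, so it remains open whether the position also tolerates a carboxylic acid, a basic dialkylamine or a longer alkyl chain. The remainder of the shared core stays fixed throughout, and only one receptor is covered, so how these substituents behave with other core changes or at related receptors is also unresolved.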